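The source may hold more compounds than are shown below. What is called first, only, known or untested is meant among the compounds shown, and "the series" means these compounds.

Measured compounds:
Compound 1, `CONC(=S)N/N=C1\C(=O)N(CN(C)C)c2ccc(C)cc21`, gives 622000 nM in an ADME assay on MT4 cells (Homo sapiens) for cytotoxicity, read by spectrophotometry, with a stated time of 5 days; on this read-out lower numbers stand for higher toxicity in this test and higher numbers for lower toxicity in this test.
Compound 2, `CCn1cc(C(=O)O)c(=O)c2cc(F)c(N3CCN(CN4C(=O)/C(=N\NC(=S)NO)c5cc(Cl)ccc54)C(C)C3)c(F)c21`, gives 209000 nM.
Compound 3, `CCN(CC)CN1C(=O)/C(=N\NC(=S)NOC)c2cc(C)ccc21`, gives 573000 nM.

Compound 1 stands at the highest of the three numbers, that is, it is the least toxic of the three in this test. Its nearest neighbour is compound 3, reached by the step of a 1.1-fold lower number from compound 1 to compound 3 (0.04 log units; within the scatter), a change on the saturated chain carbon bound to the amide-type nitrogen that leaves the read-out essentially unchanged. Compound 2 lies furthest away; its number is lower than that of compound 1, but compound 2 differs from compound 1 in many places at once, so its value says nothing about any single change.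

The unmeasured compound 4, `CONC(=S)N/N=C1\C(=O)N(CN(C)C)c2ccc(Cl)cc21`, differs from compound 1 by chloro in place of methyl on an aromatic carbon. Among the compounds with values here, no measured step touches this ring position: the only step available concerns the chain on the nitrogen and stays within the scatter. Compound 2 does carry a chloro group on its fused ring, yet it cannot be used as a guide for the reason just given. With nothing in the data pointing to a shift, the step is expected to be a 1.2-fold lower number from compound 1 to compound 4 (0.09 log units; within the scatter), within the scatter. Compound 4 is therefore estimated at 500000 nM, with a range from 250000 nM to 1000000 nM.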

Compound 4, half-maximal cytotoxic concentration: 552000 nM
For compound 4 the middle estimate is 1.1-fold (0.04 log units) below the measured one; measured number inside the range.
By their numbers in this assay, from the lowest: compound 2; then compounds 4, 3 and 1 (each within the scatter of the next).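

In this assay, within the data shown here, the change of chloro in place of methyl on an aromatic carbon, meta to a fused ring and para to a fused ring, gives a 1.1-fold lower number from compound 1 to compound 4 (0.05 log units; within the scatter) and so provides the first direct reading at this ring position. Among these compounds, the only earlier step, a 1.1-fold lower number from compound 1 to compound 3 (0.04 log units; within the scatter) on the chain carbon bound to the amide-type nitrogen, said nothing about the ring, and now a change at each of these two places stays within the scatter, which leaves compound 1, compound 3 and compound 4 close together on this read-out. No supporting data bear on why the swap of methyl for chloro leaves the number where it stands.

The compounds shown leave open whether a group of another kind on this aromatic carbon, such as methoxy, an amine or a carboxylic acid, would also leave the read-out in place. They also leave open which of the many differences of compound 2 goes with its lower number, and whether a chloro group on the core of compound 3 would read the same as the methyl group it carries.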